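From 3-cyanophenyl to 6-methoxypyridin-3-yl on compound 2

This account rests on a few compounds, and the source may have more. Where it says the series, first, only, none or still open, it means among the compounds named here.

In a functional assay on A549 cells (Homo sapiens) for antiproliferative activity, read by MTT assay, with a stated time of 72 h (a lower number here means a stronger inhibitor, a higher number a weaker inhibitor), compound 1 `C/C=C/C(=O)Nc1cccc(Oc2nc(Nc3ccn(C)n3)nc3c2CSCC3)c1` reports only a limit, > 50000 nM. Compound 2 `C/C=C/C(=O)Nc1cccc(Oc2nc(Nc3cccc(C#N)c3)nc3c2CSCC3)c1` gives 17200 nM, the lowest of the two numbers available, and compound 3 `CC(C)=CC(=O)Nc1cccc(Oc2nc(Nc3cccc(C#N)c3)nc3c2CSCC3)c1` gives 36900 nM. Compound 4 `C/C=C/C(=O)Nc1cccc(Oc2nc(Nc3ccc(OC)nc3)nc3c2CSCC3)c1` carries 6-methoxypyridin-3-yl in place of 3-cyanophenyl on a nitrogen on an aromatic ring. Within the data shown here, the closest precedent is at this same place, an at least 2.9-fold lower number from compound 1 to compound 2 (0.46 log units; beyond the scatter), and it favours 3-cyanophenyl over the only other group tried there. The step on the carbonyl carbon, a 2.1-fold higher number from compound 2 to compound 3 (0.33 log units; beyond the scatter), bears on this change less directly. The expected step in this assay is a 1.6-fold higher number from compound 2 to compound 4 (0.21 log units; within the scatter), a modest rise in the number. The estimate for compound 4 is 28000 nM, with an expected range of 9000 nM to 70000 nM.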

Compound 4, half-maximal inhibitory concentration: 8040 nM
Estimate against measurement, compound 4: 3.5-fold (0.54 log units) above; measured number below the stated range.
By their numbers in this assay, from the lowest: compound 4; then compound 2; then compound 3. At a limit, above all of these: compound 1.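

In this assay, 3-cyanophenyl is not the best group seen at this place on the nitrogen: a 2.1-fold lower number from compound 2 to compound 4 (0.33 log units; beyond the scatter). Of the three groups compared there, 6-methoxypyridin-3-yl now gives the lowest number. The wider step, an at least 6.2-fold lower number from compound 1 to compound 4 (0.79 log units; beyond the scatter), starts from a value that is a limit: the limit of > 50000 nM in this assay, at which 1 of the 4 values shown sits.

The compounds shown do not separate the pyridine ring nitrogen from the methoxy group; a plain pyridin-3-yl or a 4-methoxyphenyl would do so. Also open, from the compounds shown here alone, is whether 2-methylprop-1-en-1-yl on the carbonyl carbon would raise the number with 6-methoxypyridin-3-yl on the nitrogen.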